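A few compounds are considered here, and "the series" means these few. Any claim that something is new, unique, unknown or untested is made for them only; others in the source may bear on it.

Compound 1 `Cc1ccc(-c2nn(Cc3ccccc3)c(=O)c(C3=NS(=O)(=O)c4ccccc4N3)c2O)s1`; in an in vitro ADME assay on microsomes from liver (Macaca mulatta) for metabolic stability, tested at 5 uM (a lower number here means that the compound disappears faster, a higher number that the compound lasts longer), compound 1 gives > 1 h, which is a limit of the assay and not a number.
Compound 2 `CC(C)=Cc1nn(CCC(C)(C)C)c(=O)c(C2=NS(=O)(=O)c3cc(NS(C)(=O)=O)ccc3N2)c1O`; in this assay compound 2 gives 0.283 h.
Compound 3 `CN(c1ccc2c(c1)S(=O)(=O)N=C(c1c(O)c(-c3cccs3)nn(CCC(C)(C)C)c1=O)N2)S(C)(=O)=O`; in this assay compound 3 gives 0.112 h.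

Of the two numbers measured in this assay, compound 2 stands highest. Its nearest neighbour is compound 3, whose number lies below it by a gap that is beyond the usual scatter of repeated measurements. The result of compound 1 is only a limit, as stated in the limit of > 1 h in this assay, at which 1 of the 3 values shown sits, and gives no number to rank. For the measured compounds named here, no two of the measured compounds differ in a single place, so no measured step is available to calibrate the change that leads to compound 4.

Compound 4 `CC(C)(C)CCn1nc(C2CC2)c(O)c(C2=NS(=O)(=O)c3cc(NS(C)(=O)=O)ccc3N2)c1=O` differs from compound 2 by cyclopropyl in place of 2-methylprop-1-en-1-yl on an aromatic carbon. With no measured step of this kind among the compounds shown, the author expects the step from compound 2 to compound 4 in this assay to be a 1.2-fold higher number from compound 2 to compound 4 (0.09 log units; within the scatter), a change that stays within the scatter rather than beyond it in either direction. On that basis compound 4 is expected to give 0.35 h in this assay, with a range from 0.12 h to 1 h.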

Compound 4, half-life: 0.107 h
Compound 4: middle estimate off by 3.3-fold (0.51 log units), on the high side, and the stated range ends above it.
By their numbers in this assay, from the lowest: compounds 4 and 3 (each within the scatter of the next); then compound 2. At a limit, above all of these: compound 1.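

Cyclopropyl in place of 2-methylprop-1-en-1-yl, on the aromatic carbon next to the ring nitrogen and ortho to the hydroxy group, gives a 2.6-fold lower number from compound 2 to compound 4 (0.42 log units; beyond the scatter) in this assay. This is the first measured single change among the compounds shown, and it shows that the half-life responds to what this position carries: a group with a double bond and no ring gives way to a three-membered ring of carbon only, and the compound lasts a shorter time, not a longer one. Nothing shown gives a measured reason for this step.

On these data alone, a single pair cannot separate the loss of the double bond from the gain of the ring, so it stays open whether an isobutyl group, a saturated chain of the same carbon count as the group that leaves, would read like compound 2 or like compound 4, and what an amine at this position would do. As far as these compounds go, it is also open whether the same change would give a step of similar size with a group other than 3,3-dimethylbutyl on the ring nitrogen.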